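Swapping the Halogenated Phenyl on a Nucleoside Thioether

The source may hold more compounds than are shown below. What is called first, only, known or untested is meant among the compounds shown, and "the series" means these compounds.

Compound 1 `CCCCCNc1ncnc2c1ncn2[C@@H]1O[C@H](CO)[C@@H](O)[C@H]1O`, compound 2 `OC[C@H]1O[C@@H](n2cnc3c(CSc4ccccc4Br)ncnc32)[C@H](O)[C@@H]1O` and compound 3 `OC[C@H]1O[C@@H](n2cnc3c(CSc4c(F)cccc4Cl)ncnc32)[C@H](O)[C@@H]1O` were all tested in an assay on isolated protein for binding affinity to Equilibrative nucleoside transporter 1 (Homo sapiens); on this read-out higher numbers stand for weaker inhibition and lower numbers for stronger inhibition. Compound 1 gives 13500 nM, compound 2 gives 2400 nM and compound 3 gives 1510 nM, the lowest of the three numbers, although its gap to compound 2 lies within the scatter. Compound 4 `OC[C@H]1O[C@@H](n2cnc3c(CSc4ccccc4I)ncnc32)[C@H](O)[C@@H]1O` differs from compound 3 by 2-iodophenyl in place of 2-chloro-6-fluorophenyl on a sulfur. The step that bears on this change is a 1.6-fold lower number from compound 2 to compound 3 (0.20 log units; within the scatter), where one ring bearing halogen replaced another with little effect; the larger step of a 5.6-fold lower number from compound 1 to compound 2 (0.75 log units; beyond the scatter) touches a different part of the molecule. A move of a 1.3-fold higher number from compound 3 to compound 4 (0.12 log units; within the scatter) is therefore expected, within the scatter. Compound 4 is estimated at 2000 nM, between 900 nM and 4500 nM.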

Compound 4, half-maximal inhibitory concentration: 282 nM
The estimate for compound 4 lay 7.1-fold (0.85 log units) above the measured number; the measured number lies below the stated range.
By their numbers in this assay, from the lowest: compound 4; then compounds 3 and 2 (each within the scatter of the next); then compound 1.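

On this sulfur, the choice of halogenated ring can shift the result in this assay: 2-iodophenyl in place of 2-chloro-6-fluorophenyl gives a 5.4-fold lower number from compound 3 to compound 4 (0.73 log units; beyond the scatter), unlike the earlier ring swap, which stayed within the scatter. Iodo in place of bromo, a single-atom change, gives an 8.5-fold lower number from compound 2 to compound 4 (0.93 log units; beyond the scatter), and the distance from the pentylamino compound grows to a 48-fold lower number from compound 1 to compound 4 (1.68 log units; beyond the scatter). No evidence here accounts for this gain.

Still open, going by these compounds, is whether the iodo group is needed at all, since a plain phenyl ring would test that. A benzyl group on the sulfur, or a 2-methoxyphenyl ring, could also show how far this gain extends.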